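Hydrogen for Methyl on a Ring Oxygen

The source may report more compounds than this note shows. Statements on the series, on what has been measured and on what is new or still open speak of the compounds shown alone.

Three compounds sharing one core were tested in a functional assay on MDA-MB-231 cells (Homo sapiens) for cytotoxicity, read by sulforhodamine B assay, with a stated time of 48 h, tested at 0.001 uM; a lower number here means a stronger effect, a higher number a weaker effect of the compound at the concentration tested. Compound 1 `COc1cc(C)cc(-c2c(-c3ccnc(-c4ccc(C(C)=O)cc4)c3)cnn2CC#N)c1` gives 99% and compound 2 `Cc1cc(O)cc(-c2nn(CC#N)cc2-c2ccnc(-c3ccc(Oc4ccccc4)cc3)c2)c1` gives 96%. Compound 3 `COc1cc(C)cc(-c2nn(CC#N)cc2-c2ccnc(-c3ccc(N(C)C)cc3)c2)c1` gives 97%, the second highest of the three numbers; its nearest neighbour is compound 2 and its furthest is compound 1, and both gaps lie within the scatter, so the three cannot be told apart. Compound 4 `Cc1cc(O)cc(-c2nn(CC#N)cc2-c2ccnc(-c3ccc(N(C)C)cc3)c2)c1` has not yet been measured. It differs from compound 3 by hydrogen in place of methyl on an oxygen on an aromatic ring. Because compound 2, which already carries the hydroxy form, gives 96% in this assay, no step beyond the scatter is expected. The step expected, a number 1 percentage points lower from compound 3 to compound 4 (within the scatter), stays within the scatter. Compound 4 is therefore estimated at 96%, within a range from 88% to 101%.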

Compound 4, a percentage reported as activity, at one concentration (the size of the read-out at that concentration, not a potency): 99%
The estimate for compound 4 lay 3 percentage points below the measured number, within the range that was stated.
By their numbers in this assay, from the lowest: compounds 2, 3, 1 and 4 (each within the scatter of the next).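

In this assay, among the compounds shown here, hydrogen in place of methyl on the oxygen of the aromatic ring gives a number 2 percentage points higher from compound 3 to compound 4 (within the scatter) in the first direct pair for this change, so methoxy and hydroxy cannot be told apart here. With the hydroxy form kept, dimethylamino in place of phenoxy gives a number 3 percentage points higher from compound 2 to compound 4 (within the scatter) and those two compounds cannot be told apart either. Open, as far as these compounds go, is whether an amine or a carboxylic acid at this ring position, or a longer chain such as ethoxy on the oxygen, would give a number beyond the scatter. No evidence bears on this result.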